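The compounds below may be only part of what the source reports. "The series", "measured", "known", "first", "only" and "open" are said of these compounds alone.

Measured in a functional assay on cells (T-cell, Homo sapiens) for inhibition; a higher number here means a weaker inhibitor, a lower number a stronger inhibitor:
Compound 1 `COc1ccc(-c2cnc3nc(N)nc(N4CCN(Cc5ccccc5F)CC4)c3n2)cc1OC` gives 700 nM.
Compound 2 `COc1ccc(-c2cnc3nc(N)nc(N4CCN(c5ccc(C)cc5)CC4)c3n2)cc1OC` gives 300 nM.
Compound 3 `COc1ccc(-c2cnc3nc(N)nc(OC(C)C)c3n2)cc1` gives no number, only a limit of the assay, > 10000 nM.

Compound 2 holds the lowest of the two numbers shown; the nearest is compound 1, with a 2.3-fold lower number from compound 1 to compound 2 (0.37 log units; beyond the scatter). The value of compound 3 sits at the limit of > 10000 nM in this assay, at which 1 of the 3 values shown sits, so it carries no number to compare.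

Compound 4 `COc1ccc(-c2cnc3nc(N)nc(N4CCN(C(=O)CCc5ccccc5)CC4)c3n2)cc1OC` differs from compound 2 in one place: phenethylcarbonyl in place of 4-methylphenyl on an amine nitrogen in a ring. Within the data shown here, the only measured step that touches this ring nitrogen is a 2.3-fold lower number from compound 1 to compound 2 (0.37 log units; beyond the scatter), a modest gain when an aryl group replaced a benzyl group. The present change moves away from that aryl group to a phenethylcarbonyl, a group of a different kind, so a step of similar modest size in the opposite direction, towards a higher number, seems the most likely outcome, though a change within the scatter cannot be ruled out. Compound 4 is therefore expected to give about 700 nM, within a range from 250 nM to 2500 nM. The expected step is a 2.3-fold higher number from compound 2 to compound 4 (0.37 log units; beyond the scatter).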

Compound 4, half-maximal inhibitory concentration: 100 nM
Compound 4: middle estimate off by 7.0-fold (0.85 log units), on the high side; the whole stated range lies above it.
By their numbers in this assay, from the lowest: compound 4; then compound 2; then compound 1. At a limit, above all of these: compound 3.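

In this assay, the amine nitrogen in the ring accepts more than an aryl or a benzyl group: replacing those groups with phenethylcarbonyl gives a 3.0-fold lower number from compound 2 to compound 4 (0.48 log units; beyond the scatter) and a 7.0-fold lower number from compound 1 to compound 4 (0.85 log units; beyond the scatter). The phenyl ring therefore need not stand directly on this nitrogen, and a carbonyl can stand there, with the larger group giving the lowest number of the three compounds with measured values. Nothing measured here explains why this change lowers the number.

Going by these compounds, it remains open whether the gain comes from the carbonyl or from the chain that carries the phenyl ring. A phenylpropyl group on the same nitrogen would test the carbonyl, while benzoyl or acetyl groups would test the chain and the phenyl ring.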